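A few compounds are considered here, and "the series" means these few. Any claim that something is new, unique, unknown or untested is made for them only; others in the source may bear on it.

Compound 1 `CC1CCN(Cc2ccc3nc(NC(=O)N/N=C/c4cn(Cc5ccccc5Cl)c5ccccc45)sc3c2)CC1`: 3330 nM
Compound 2 `CC1CCN(Cc2ccc3nc(NC(=O)N/N=C/c4cn(Cc5ccccc5)c5ccccc45)sc3c2)CC1`: 2340 nM
Compound 3 `CC1CCN(Cc2ccc3nc(NC(=O)N/N=C/c4cn(Cc5ccc(Cl)cc5)c5ccccc45)sc3c2)CC1`: 2030 nM

In a functional assay on A549 cells (Homo sapiens) for cytotoxicity, read by MTT assay, with a stated time of 72 h (on this read-out lower numbers stand for stronger inhibition and higher numbers for weaker inhibition), compound 3 gives 2030 nM, which cannot be separated from the other two values: a 1.2-fold lower number from compound 2 to compound 3 (0.06 log units; within the scatter) and a 1.6-fold lower number from compound 1 to compound 3 (0.21 log units; within the scatter). Compound 4 `CC1CCN(Cc2ccc3nc(NC(=O)N/N=C/c4cn(Cc5ccc(C(C)(C)C)cc5)c5ccccc45)sc3c2)CC1` differs from compound 3 as follows: tert-butyl in place of chloro on an aromatic carbon. Within the data shown here, no measured compound carries tert-butyl, so the nearest evidence is indirect. The chloro group at this place gave a 1.2-fold lower number from compound 2 to compound 3 (0.06 log units; within the scatter), and moving it gave a 1.6-fold lower number from compound 1 to compound 3 (0.21 log units; within the scatter), while its removal gave a 1.4-fold lower number from compound 1 to compound 2 (0.15 log units; within the scatter). In this assay the expected step is therefore none beyond the scatter, and it is estimated as a 1.1-fold higher number from compound 3 to compound 4 (0.05 log units; within the scatter). Compound 4 is expected at 2300 nM, with an estimated range of 1000 nM to 5000 nM.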

Compound 4, half-maximal inhibitory concentration: 3710 nM
For compound 4 the middle estimate is 1.6-fold (0.21 log units) below the measured one, and the stated range covers the measured number.
By their numbers in this assay, from the lowest: compounds 3, 2, 1 and 4 (each within the scatter of the next).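

In this assay, tert-butyl on this aromatic carbon, para to a large group, gives no step beyond the scatter from any earlier compound (a 1.8-fold higher number from compound 3 to compound 4 (0.26 log units; within the scatter); a 1.6-fold higher number from compound 2 to compound 4 (0.20 log units; within the scatter); a 1.1-fold higher number from compound 1 to compound 4 (0.05 log units; within the scatter)). The position therefore accepts tert-butyl, with its 4 heavy atoms, as well as chloro or hydrogen, and these compounds cannot be told apart by their numbers. No measurement available here accounts for this. On these data alone, whether an amine or a carboxylic acid at this place would give a step beyond the scatter remains open.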